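The compounds below may be only part of what the source reports. "The series", "measured", "known", "first", "only" and "open" are said of these compounds alone.

Measured so far:
Compound 1, `C[C@@H]1CN(c2ccc(C(F)(F)F)cn2)[C@@H](C)CN1S(=O)(=O)C[C@]12CC[C@H](CC1=O)C2(C)C`: in a functional assay on CHO-K1 cells for antagonist activity at C-X-C chemokine receptor type 3 (Homo sapiens), read by FLIPR and calcium flux (on this read-out higher numbers stand for weaker inhibition and lower numbers for stronger inhibition), compound 1 gives 6310 nM.
Compound 2, `C[C@H]1CN(S(=O)(=O)C[C@]23CC[C@H](CC2=O)C3(C)C)CCN1c1ccc(C(F)(F)F)cn1`: compound 2 gives 158 nM.
Compound 3, `CC1(C)[C@@H]2CC[C@@]1(CS(=O)(=O)N1CCN(c3ccc(C(F)(F)F)cn3)CC1)C(O)C2`: compound 3 gives 158 nM.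

For the measured compounds named here, the one counted step is a 40-fold higher number from compound 2 to compound 1 (1.60 log units; beyond the scatter), made by methyl in place of hydrogen on a saturated ring carbon. Compound 3 and compound 2 give the same number at the digits shown; the difference between their two cores is not broken down here.

Compound 4, `CC1(O)C[C@H]2CC[C@]1(CS(=O)(=O)N1CCN(c3ccc(C(F)(F)F)cn3)CC1)C2(C)C`, is not yet measured. It arises from compound 3 by methyl in place of hydrogen on a saturated ring carbon. This is the same kind of change as that from compound 2 to compound 1, but the place differs: there the methyl entered a six-membered non-aromatic ring with two nitrogens, next to the ring nitrogen; here it enters a five-membered non-aromatic ring of carbon only, part of a fused or bridged system of two rings, next to the ring atom that bears a fused ring. That earlier step, a 40-fold higher number from compound 2 to compound 1 (1.60 log units; beyond the scatter), arose at a different place, so it is not expected to carry over in full, and a smaller step is expected: a 2.2-fold higher number from compound 3 to compound 4 (0.35 log units; beyond the scatter). Compound 4 is expected to give about 350 nM in this assay, estimated to lie between 100 nM and 1600 nM.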

Compound 4, half-maximal inhibitory concentration: 200 nM
Estimate against measurement, compound 4: 1.8-fold (0.24 log units) above, and the stated range covers the measured number.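

In this assay, methyl in place of hydrogen on a saturated ring carbon gives a 1.3-fold higher number from compound 3 to compound 4 (0.10 log units; within the scatter). Set beside the earlier step, this shows that the change does not carry over from one core to another with a fixed size: the same change on two cores in this assay, a 40-fold higher number (1.60 log units; beyond the scatter) from compound 2 to compound 1 and a 1.3-fold higher number (0.10 log units; within the scatter) from compound 3 to compound 4, 32-fold (1.50 log units) apart, beyond the scatter of two such steps. It does not show what sets the gap, as the two steps differ both in the core and in the ring that takes the methyl, and the data do not separate these two differences.

The compounds shown leave open whether an ethyl group or a longer chain on the same ring carbon would also leave the number within the scatter of compound 3. They also leave open what an amine at that carbon would do.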